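A few compounds are considered here, and "the series" means these few. Any claim that something is new, unique, unknown or untested is made for them only; others in the source may bear on it.

In a functional assay on DU-145 cells (Homo sapiens) for cytotoxicity, read by MTT assay (on this read-out lower numbers stand for stronger inhibition and higher numbers for weaker inhibition), compound 1 `CC(=O)OCCC(=O)O[C@H](CC=C(C)C)C1=CC(=O)c2c(O)ccc(O)c2C1=O` gives 15700 nM. Compound 2 `CCCCCCC(C)(O)CC(=O)O[C@H](CC=C(C)C)C1=CC(=O)c2c(O)ccc(O)c2C1=O` gives only a limit, > 100000 nM. Compound 3 `CCCC(CC(=O)O[C@H](CC=C(C)C)C1=CC(=O)c2c(O)ccc(O)c2C1=O)OC(C)=O` differs from compound 2 by 1-acetoxybutyl in place of 1-hydroxy-1-methylheptyl on a saturated chain carbon bound to a carbonyl carbon, with 1-acetoxybutyl in place of 1-hydroxy-1-methylheptyl on a saturated chain carbon bound to a carbonyl carbon. Among the measured compounds shown here, the one measured step bearing on this is an at least 6.3-fold higher number from compound 1 to compound 2 (0.80 log units; beyond the scatter), where 1-hydroxy-1-methylheptyl replaced acetoxymethyl. The 1-acetoxybutyl group restores an acetoxy unit, so a return towards compound 1 at 15700 nM is expected, a change of at least similar size in the opposite direction. The expected step is an at least 4.0-fold lower number from compound 2 to compound 3 (0.60 log units; beyond the scatter). Compound 3 is estimated at 25000 nM, with an expected range of 8000 nM to 80000 nM.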

Compound 3, half-maximal inhibitory concentration: 55700 nM
Compound 3: the middle estimate sits 2.2-fold (0.35 log units) below what was measured; the measured number falls inside the stated range.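

In this assay, keeping the acetoxy unit is not enough to hold the value of compound 1: propyl in place of hydrogen on a saturated chain carbon bound to an oxygen next to a carbonyl group and a saturated chain carbon gives a 3.5-fold higher number from compound 1 to compound 3 (0.55 log units; beyond the scatter). The exchange of 1-hydroxy-1-methylheptyl for 1-acetoxybutyl gives an at least 1.7-fold lower number from compound 2 to compound 3 (0.25 log units; that floor lies within the scatter), but that floor lies within the scatter. The value for compound 2 is a limit: the limit of > 100000 nM in this assay, at which 1 of the 3 values shown sits.

On these data alone, whether ethyl or methyl in place of that propyl would give a value closer to compound 1 remains open. So does the effect of an amine in place of the acetoxy unit.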